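The source may hold more compounds than are shown below. What is called first, only, known or untested is meant among the compounds shown, and "the series" means these compounds.

In an assay on isolated protein for inhibition of serine/threonine-protein kinase PAK 1 (Homo sapiens), read by ADP-Glo, with a stated time of 40 min (on this read-out lower numbers stand for stronger inhibition and higher numbers for weaker inhibition), compound 1 `O=C(NC1CCN(c2ncnc3[nH]ncc23)CC1)c1ccccc1Cl` gives 5240 nM, and compound 2 `O=C(Nc1ccc(Cl)c(Cl)c1)NC1CCN(c2ncnc3[nH]ncc23)CC1` gives 2290 nM, the lower of the two numbers shown. Within the data shown here, the only measured step, a 2.3-fold lower number from compound 1 to compound 2 (0.36 log units; beyond the scatter), changed the aryl group and the link to it at once, so it gives no clean reading on an aryl swap alone. Compound 3 `O=C(Nc1ccc(F)cc1F)NC1CCN(c2ncnc3[nH]ncc23)CC1` keeps the urea of compound 2 and differs only in 2,4-difluorophenyl in place of 3,4-dichlorophenyl on an amide-type nitrogen. Among the measured compounds shown here, with no direct precedent, the expected step is small, a 1.4-fold higher number from compound 2 to compound 3 (0.15 log units; within the scatter), likely within the scatter. Compound 3 is therefore estimated at 3200 nM, between 1200 nM and 8500 nM.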

Compound 3, half-maximal inhibitory concentration: 1140 nM
Estimate against measurement, compound 3: 2.8-fold (0.45 log units) above; the measured number lies below the stated range.
By their numbers in this assay, from the lowest: compounds 3 and 2 (each within the scatter of the next); then compound 1.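

Among these compounds, the first aryl swap on an amide-type nitrogen with the link held fixed, a 2.0-fold lower number from compound 2 to compound 3 (0.30 log units; within the scatter), shows that this assay does not separate 2,4-difluorophenyl from 3,4-dichlorophenyl. The larger step, a 4.6-fold lower number from compound 1 to compound 3 (0.66 log units; beyond the scatter), changes the aryl group and the link together, so neither change can be credited alone. Nothing available explains either step. Still open, going by these compounds, is what the urea link contributes by itself, which a urea carrying 2-chlorophenyl would show, and whether a pyridine ring or a methoxy group on the phenyl ring would shift the number beyond the scatter.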